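Aryl group on the ring nitrogen: dimethylphenyl isomers

A few compounds are considered here, and "the series" means these few. Any claim that something is new, unique, unknown or untested is made for them only; others in the source may bear on it.

In a functional assay on HepG2 cells (Homo sapiens) for antiproliferative activity, read by MTT assay, with a stated time of 48 h (on this read-out lower numbers stand for stronger inhibition and higher numbers for weaker inhibition), compound 3 `Cc1ccc(C)c(-n2nncc2CN2C(=O)C3(C(C#N)=C(N)Oc4c3c3nc5ccccc5nc3c3ccccc43)c3ccccc32)c1` gives only the limit > 50000 nM. Compound 1 `N#CC1=C(N)Oc2c(c3nc4ccccc4nc3c3ccccc23)C12C(=O)N(Cc1cnnn1-c1cccc(Cl)c1)c1ccccc12` sits at a limit as well, > 50000 nM. Compound 2 `N#CC1=C(N)Oc2c(c3nc4ccccc4nc3c3ccccc23)C12C(=O)N(Cc1cnnn1-c1ccc([N+](=O)[O-])cc1)c1ccccc12` likewise reaches only the limit > 50000 nM. The changes among them, a step that the two limits leave unreadable from compound 1 to compound 2, a step that the two limits leave unreadable from compound 1 to compound 3 and a step that the two limits leave unreadable from compound 2 to compound 3, cannot be sized, because of the limit of > 50000 nM in this assay, at which 3 of the 3 values shown sit. Compound 4 `Cc1cc(C)cc(-n2nncc2CN2C(=O)C3(C(C#N)=C(N)Oc4c3c3nc5ccccc5nc3c3ccccc43)c3ccccc32)c1` differs from compound 3 by 3,5-dimethylphenyl in place of 2,5-dimethylphenyl on an aromatic nitrogen. All three measured steps concern the aryl group on this same nitrogen, and none has a readable size. The expected step is therefore a step that the limit leaves unreadable from compound 3 to compound 4, with no direction readable. Compound 4 is expected to give 80000 nM in this assay, estimated between 20000 nM and 300000 nM, most likely again only a limit.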

Compound 4, half-maximal inhibitory concentration: > 50000 nM
Compound 4 gave a limit, no number; the forecaster's own chance of this, stated with the estimate: 85%; the middle value does not contradict the limit.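

Compound 4 gives only the limit > 50000 nM in this assay, so its steps from compound 1, compound 2 and compound 3 cannot be read: the limit of > 50000 nM in this assay, at which 4 of the 4 values shown sit.

The compounds shown leave open whether any aryl group on this nitrogen gives a measurable value in this assay.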